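Aryl fluorine in a diethylamino-triazine series

The source may hold more compounds than are shown below. What is called first, only, known or untested is meant among the compounds shown, and "the series" means these compounds.

Measured compounds:
compound 1, `CCN(CC)c1nc(Nc2cccc(F)c2)nc(OC(C(F)(F)F)C(F)(F)F)n1`, 140 nM
compound 2, `CCN(CC)c1nc(Nc2ccccc2)nc(OCC(F)(F)C(F)F)n1`, 2000 nM

In an assay on cells for activation of Cystic fibrosis transmembrane conductance regulator (Homo sapiens), read by fluorescence, with stated times of 10 min and 12 s (on this read-out higher numbers stand for an effect only at larger amounts of compound and lower numbers for an effect already at smaller amounts), compound 2 gives 2000 nM, the highest of the two numbers; the nearest is compound 1 with 140 nM, a gap well beyond the scatter. Going by the values given here, compounds 1 and 2 differ in two places, so no single step connects them, and only their two values are known.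

Compound 3, `CCN(CC)c1nc(Nc2cccc(F)c2)nc(OCC(F)(F)C(F)F)n1`, differs from compound 2 by fluoro in place of hydrogen on an aromatic carbon. As far as these compounds go, the other change that separates compound 1 from compound 2 is not made here, so the share of the fluorine in the gap between them is unknown. The expectation is a modest lowering of the number, a 2.2-fold lower number from compound 2 to compound 3 (0.35 log units; beyond the scatter), with a wide spread. Compound 3 is estimated at 900 nM, between 300 nM and 3000 nM.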

Compound 3, half-maximal effective concentration: 1600 nM
Beside the measured number, compound 3's estimate is 1.8-fold (0.25 log units) below it; low and high end bracket the measured number.
By their numbers in this assay, from the lowest: compound 1; then compounds 3 and 2 (each within the scatter of the next).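

In this assay the change from anilino to (3-fluorophenyl)amino, with 2,2,3,3-tetrafluoropropyl on the oxygen, gives a 1.3-fold lower number from compound 2 to compound 3 (0.10 log units; within the scatter) and so does not separate the two compounds. Going by these compounds alone, the step beyond the scatter lies at the oxygen: with (3-fluorophenyl)amino held constant, 2,2,3,3-tetrafluoropropyl in place of 2,2,2-trifluoro-1-(trifluoromethyl)ethyl gives an 11-fold higher number from compound 1 to compound 3 (1.06 log units; beyond the scatter) and is the only single change here that moves the number clearly. No measurement at hand gives a reason for either step.

The compounds shown leave open whether phenyl in place of 3-fluorophenyl would also stay within the scatter with 2,2,2-trifluoro-1-(trifluoromethyl)ethyl on the oxygen. Also open, as far as these compounds go, is how chloro, methoxy or an amine on this aromatic carbon would read.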